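Paw edema series: a 3-aminopropyl chain on the ring nitrogen

The source may report more compounds than this note shows. Statements on the series, on what has been measured and on what is new or still open speak of the compounds shown alone.

Compound 2 `COc1ccc(F)cc1-c1cccc(-c2n[nH]c(=O)o2)c1` gives 41% in a functional assay on the whole organism (strain Wistar albino) for inhibition, with Rattus norvegicus as the target, read by paw edema, with stated times of 30 min and 1 h, at a dose of 10 mg/kg by the oral route (on this read-out lower numbers stand for less inhibition and higher numbers for more inhibition at the one dose given (going by the name of the read-out)), the second highest of the three numbers measured. Compound 1 `COc1ccc(F)cc1-c1cccc(-c2nn(CCCC#N)c(=O)o2)c1` gives 44%, and compound 3 `COc1ccc(F)cc1-c1cccc(-c2nn(CCOC3CCCCO3)c(=O)o2)c1` gives 32%. The step of a number 3 percentage points lower from compound 1 to compound 2 (within the scatter) and the step of a number 9 percentage points lower from compound 2 to compound 3 (within the scatter) both lie within the scatter; only a number 12 percentage points lower from compound 1 to compound 3 (beyond the scatter) goes beyond it.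

Compound 4 `COc1ccc(F)cc1-c1cccc(-c2nn(CCCN)c(=O)o2)c1` differs from compound 2 by 3-aminopropyl in place of hydrogen on an aromatic nitrogen. The two steps that bear on this change, both of which alter the group on the aromatic nitrogen, are a number 3 percentage points lower from compound 1 to compound 2 (within the scatter) and a number 9 percentage points lower from compound 2 to compound 3 (within the scatter); neither moved the read-out beyond the scatter. A step of a number 1 percentage points higher from compound 2 to compound 4 (within the scatter) is therefore expected, none beyond the scatter. For compound 4 a value of 42% is estimated, within 30% to 54%.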

Compound 4, a percentage reported as inhibition, in the whole organism at one dose (the size of the read-out at that dose, not a potency): 43%
Beside the measured number, compound 4's estimate is 1 percentage points below it; measured number inside the range.
By their numbers in this assay, from the lowest: compounds 3, 2, 4 and 1 (each within the scatter of the next, the first and the last beyond it).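

In this assay, 3-aminopropyl in place of hydrogen on the aromatic nitrogen gives a number 2 percentage points higher from compound 2 to compound 4 (within the scatter), and amino in place of cyano at the chain end gives a number 1 percentage points lower from compound 1 to compound 4 (within the scatter), so this position accepts a terminal amine without a shift beyond the scatter. Aminomethyl in place of (oxan-2-yl)oxy gives a number 11 percentage points higher from compound 3 to compound 4 (beyond the scatter), which sets compound 4 apart from compound 3 as well. Nothing at hand explains these numbers.

From the compounds shown here alone, whether a carboxylic acid at the chain end or a longer aminoalkyl chain would move the read-out beyond the scatter of compound 2 remains open. So does the effect of a dimethylamino end group.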